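Fluoro-methylphenyl variant of a stable aminopyrimidine nitrile

The source may report more compounds than this note shows. Statements on the series, on what has been measured and on what is new or still open speak of the compounds shown alone.

Compound 1 `Cc1cccc(-c2c([C@H](C)Nc3nc(N)nc(N)c3C#N)cc3ccc(F)cn3c2=O)c1`: < 1%
Compound 2 `C[C@H](Nc1nc(N)nc(N)c1C#N)c1cc2ccc(F)cn2c(=O)c1-c1ccc(F)cc1`: 84%
Compound 3 `Cc1cc(F)cc(-c2c([C@H](C)Nc3nc(N)nc(N)c3C#N)cc3ccc(F)cn3c2=O)c1`: to be measured

For the measured compounds named here, in an ADME assay on microsomes from liver (Mus musculus), read by LC-MS, using NADPH, with a stated time of 30 min, tested at 1 uM (a higher number here means that more of the compound is left, a lower number that less of the compound is left), compound 2 gives 84%, the only plain number among the two results. Compound 1 sits at the limit (the limit of < 1% in this assay, at which 1 of the 2 values shown sits). The step of a number at least 83 percentage points higher from compound 1 to compound 2 (beyond the scatter) is the sole measured one and is large. Compound 3 carries 3-fluoro-5-methylphenyl in place of 4-fluorophenyl on an aromatic carbon, which reintroduces a methyl like that of compound 1 together with a fluorine. Expected is a drop a number 59 percentage points lower from compound 2 to compound 3 (beyond the scatter) to a middling value, landing compound 3 at an estimated 25%, within 3% to 65%.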

Compound 3, percent of the compound remaining: < 1%
Compound 3 gave a limit, no number (the forecaster's own chance of this, stated with the estimate: 15%); middle value at least 24 percentage points from the limit.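

In this assay, 3-fluoro-5-methylphenyl in place of 4-fluorophenyl on this aromatic carbon brings a number at least 83 percentage points lower from compound 2 to compound 3 (beyond the scatter), so having a fluorine on the phenyl ring does not by itself preserve the high value of compound 2. The value of compound 3, < 1%, is a limit and not a number: the limit of < 1% in this assay, at which 2 of the 3 values shown sit.

The step from compound 1 to compound 3, fluoro in place of hydrogen, cannot be read. As far as these compounds go, whether the methyl group alone sets the low values stays open, as does the result for a phenyl ring carrying a methoxy group or an amine.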